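The source may report more compounds than this note shows. Statements on the series, on what has been measured and on what is new or still open speak of the compounds shown alone.

Compound 1 `Cc1ccnc2nc(-c3cccc(Cl)c3)cc(O)c12`: 25700 nM
Compound 2 `Cc1ccc2c(O)cc(-c3cccc(Cl)c3)nc2n1`: 21400 nM

In a functional assay on cells (Tumor Cell line, Homo sapiens) for inhibition (a lower number here means a stronger inhibitor of growth, a higher number a weaker inhibitor of growth), compound 2 gives 21400 nM, which lies within the scatter of compound 1 at 25700 nM. Compound 3 `Oc1cc(-c2cccc(Cl)c2)nc2ncccc12` has hydrogen in place of methyl on an aromatic carbon. Among the compounds with values here, no measured pair shows this change on its own, and the two values give no sign of a large effect, so no change beyond the scatter is expected in this assay. The expected result is a small step of a 1.2-fold higher number from compound 2 to compound 3 (0.08 log units; within the scatter), with no firm direction. For compound 3 the estimated value is 26000 nM, with an expected range of 13000 nM to 52000 nM.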

Compound 3, concentration for total growth inhibition: 24000 nM
The estimate for compound 3 lay 1.1-fold (0.03 log units) above the measured number, and the stated range covers the measured number.
By their numbers in this assay, from the lowest: compounds 2, 3 and 1 (each within the scatter of the next).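

In this assay, hydrogen in place of methyl on an aromatic carbon next to the ring nitrogen gives a 1.1-fold higher number from compound 2 to compound 3 (0.05 log units; within the scatter), and the same exchange at the other methyl position gives a 1.1-fold lower number from compound 1 to compound 3 (0.03 log units; within the scatter). Within the data shown here, for the first time, the methyl at each of these places can be judged on its own, and neither shows an effect beyond the scatter. Nothing available explains this result. Going by these compounds, whether an amine, a carboxylic acid or a longer chain at these places would shift the number beyond the scatter stays open.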